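This account rests on a few compounds, and the source may have more. Where it says the series, first, only, none or still open, it means among the compounds named here.

Compound 3 `COc1ccnc(Nc2cc3[nH]c(-c4cccc(C(F)(F)F)c4)nc3cn2)c1` in a physicochemical assay for solubility, using the shake flask method, in phosphate buffer, measured as kinetic solubility, with a stated time of 20 h, at pH 6.5 (a higher number here means a more soluble compound, a lower number a less soluble compound), gives only a limit, < 5000 nM. Compound 1 `FC(F)(F)Oc1ccc(-c2nc3cnc(Nc4ccccn4)cc3[nH]2)cc1` likewise returns a limit in this assay, < 5000 nM. Compound 2 `COc1cccc(Nc2cc3[nH]c(-c4cccc(C(F)(F)F)c4)nc3cn2)n1` also stands at a limit in this assay, < 5000 nM. For the measured compounds named here, all three values sit at the limit of < 5000 nM in this assay, at which 3 of the 3 values shown sit, so compound 3 cannot be placed within the set beyond this point, and the single measured step, a step that the two limits leave unreadable from compound 2 to compound 3, concerns a different change and yields no size. Compound 4 `FC(F)(F)c1cccc(-c2nc3cnc(Nc4ccncn4)cc3[nH]2)c1` differs from compound 3 as pyrimidin-4-yl in place of 4-methoxypyridin-2-yl on a nitrogen on an aromatic ring. Going by the values given here, no measured step bears on this change, and the rest of compound 3, including the shared core, is kept. With all three measured compounds resting at the same limit, compound 4 is expected to remain near it as well. The step that the limit leaves unreadable from compound 3 to compound 4 is estimated to stay within the scatter, with no direction to be read. Compound 4 is expected at 3500 nM, in a range from 800 nM to 15000 nM, and this assay is likely to report only a limit once more.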

Compound 4, solubility: < 5000 nM
Compound 4: a limit, no number; the forecaster's own chance of this, stated with the estimate: 70%; the middle value does not contradict the limit.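

In this assay compound 4 gives only a limit, < 5000 nM, so the steps to it from compound 2 and compound 3 cannot be read. How compounds 1 to 4 rank in solubility, and what pyrimidin-4-yl changes in place of 4-methoxypyridin-2-yl or 6-methoxypyridin-2-yl, stays open: the limit of < 5000 nM in this assay, at which 4 of the 4 values shown sit.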